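The source may report more compounds than this note shows. Statements on the series, on what has been measured and on what is new or still open speak of the compounds shown alone.

Measured so far in a functional assay on Bel-7402 cells (Homo sapiens) for cytotoxicity, read by MTT assay; a higher number here means a weaker inhibitor, a lower number a stronger inhibitor:
Compound 1 `CCn1cc(C(=O)Nc2ccccc2)c(=O)c2cc(F)c(N3CCNC(C)C3)c(F)c21` gives 6000 nM
Compound 2 `CCn1cc(C(=O)Nc2ccc(C)c([N+](=O)[O-])c2)c(=O)c2cc(F)c(N3CCNC(C)C3)c(F)c21` gives 29100 nM
Compound 3 `CCn1cc(C(=O)Nc2cc([N+](=O)[O-])ccc2F)c(=O)c2cc(F)c(N3CCNC(C)C3)c(F)c21` gives 2900 nM

Among these three, compound 1 stands second highest: compound 3 gives a lower number, a 2.1-fold lower number from compound 1 to compound 3 (0.32 log units; beyond the scatter), while compound 2 gives a higher one, a 4.9-fold higher number from compound 1 to compound 2 (0.69 log units; beyond the scatter). Compound 4 `CCn1cc(C(=O)Nc2ccc(OC(F)(F)F)cc2)c(=O)c2cc(F)c(N3CCNC(C)C3)c(F)c21` differs from compound 1 by a single change: trifluoromethoxy in place of hydrogen on an aromatic carbon. Going by the values given here, no measured step introduces a trifluoromethoxy, so the known steps bear on this only indirectly. Both alter the same aromatic ring on the amide-type nitrogen and pull in opposite directions, one modestly up and one modestly down, with a 10-fold lower number from compound 2 to compound 3 (1.00 log units; beyond the scatter) separating them. A small step, within or barely beyond the scatter, is therefore expected for compound 4, which in this assay is estimated at 5000 nM (range 1500 nM to 16000 nM), an expected step of a 1.2-fold lower number from compound 1 to compound 4 (0.08 log units; within the scatter).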

Compound 4, half-maximal inhibitory concentration: 2000 nM
The estimate for compound 4 lay 2.5-fold (0.40 log units) above the measured number; the range from low to high includes it.
By their numbers in this assay, from the lowest: compounds 4 and 3 (each within the scatter of the next); then compound 1; then compound 2.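

Trifluoromethoxy on the aromatic carbon para to a large group gives a 3.0-fold lower number from compound 1 to compound 4 (0.48 log units; beyond the scatter) in this assay, so this one group on the anilide ring lowers the number without any nitro group on that ring. The ring of compound 4 cannot be told apart from the nitro-bearing ring of compound 3, with a 1.5-fold lower number from compound 3 to compound 4 (0.16 log units; within the scatter), yet it stands well away from the ring of compound 2, with a 15-fold lower number from compound 2 to compound 4 (1.16 log units; beyond the scatter). Nothing measured here explains these steps. Still open, going by these compounds, is whether an amine or a carboxylic acid at this position would also lower the number.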